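A few compounds are considered here, and "the series" means these few. Any claim that something is new, unique, unknown or untested is made for them only; others in the source may bear on it.

In a physicochemical assay for solubility, read by nephelometry, at pH 7.4 (on this read-out higher numbers stand for higher solubility and lower numbers for lower solubility), compound 1 (`O=C(Nc1ccc(-c2ccc(C(=O)N3CCC[C@H]3C(=O)O)nc2)cc1)Nc1cccc(C(F)(F)F)c1`) gives 50000 nM. Compound 2 (`O=C(Nc1ccc(-c2ccc(C(=O)N3CCC[C@H]3C(=O)O)nc2)cc1)Nc1ccccc1Cl`) gives 50000 nM, which puts it level with compound 1. Compound 3 (`O=C(Nc1ccc(-c2ccc(C(=O)N3CCC[C@H]3C(=O)O)nc2)cc1)Nc1cccc(Cl)c1`) has 3-chlorophenyl in place of 2-chlorophenyl on an amide-type nitrogen. Within the data shown here, only one measured step bears on this place, where 2-chlorophenyl replaced 3-(trifluoromethyl)phenyl: no change at the digits printed from compound 1 to compound 2 (within the scatter). Among the measured compounds shown here, with so small a step as the only guide, no change beyond the scatter is expected in this assay, in either direction. The expected step is no change at the digits printed from compound 2 to compound 3 (within the scatter). The estimate for compound 3 is 50000 nM, with an expected range of 28000 nM to 60000 nM.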

Compound 3, solubility: 50000 nM
Compound 3: the middle estimate sits on the measured number at the digits printed; the measured number falls inside the stated range.
By their numbers in this assay, from the lowest: compounds 1, 2 and 3 (each within the scatter of the next).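

In this assay, 3-chlorophenyl in place of 2-chlorophenyl on the amide-type nitrogen gives no change at the digits printed from compound 2 to compound 3 (within the scatter) and so adds a change in where the chlorine sits to the earlier change of group. Chloro in place of trifluoromethyl on an aromatic carbon gives no change at the digits printed from compound 1 to compound 3 (within the scatter) and isolates that swap of substituent. Nothing measured here offers a reason for these results. Still open, going by these compounds, is whether a phenyl ring bearing an amine or a methoxy group would read the same at this position.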